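Cyclopentyl for Pentyl on a Weak Phosphodiesterase Scaffold

The compounds below may be only part of what the source reports. "The series", "measured", "known", "first", "only" and "open" are said of these compounds alone.

Measured so far:
compound 1 `COCCCNc1ccnc2c1nc(-c1ccco1)n2C1CCCC1`, 90500 nM
compound 2 `CCCCCn1c(-c2ccco2)nc2c(NCCCO)ccnc21`, 63600 nM

In an assay on isolated protein for inhibition of high affinity 3',5'-cyclic-AMP phosphodiesterase 7A (Homo sapiens), read by cAMP accumulation, with a stated time of 20 min (a lower number here means a stronger inhibitor, a higher number a weaker inhibitor), compound 2 gives 63600 nM, the lower of the two numbers, while compound 1 gives 90500 nM; the two lie within the scatter, so no order between them can be claimed. Compound 3 `OCCCNc1ccnc2c1nc(-c1ccco1)n2C1CCCC1` differs from compound 2 by cyclopentyl in place of pentyl on an aromatic nitrogen. Going by the values given here, no step between measured compounds is available to calibrate this change. With both measured values so close, the step of a 1.1-fold higher number from compound 2 to compound 3 (0.04 log units; within the scatter) is expected to stay within the scatter in either direction. Compound 3 is therefore estimated at 70000 nM, within 25000 nM to 200000 nM.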

Compound 3, half-maximal inhibitory concentration: 88000 nM
For compound 3 the middle estimate is 1.3-fold (0.10 log units) below the measured one, and the stated range covers the measured number.
By their numbers in this assay, from the lowest: compounds 2, 3 and 1 (each within the scatter of the next).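

In this assay, cyclopentyl in place of pentyl on the aromatic nitrogen gives a 1.4-fold higher number from compound 2 to compound 3 (0.14 log units; within the scatter), so a ring of the same five carbons leaves the number within the scatter at this position. Hydrogen in place of methyl on an oxygen on a saturated carbon gives a 1.0-fold lower number from compound 1 to compound 3 (0.01 log units; within the scatter), which is also within the scatter, so neither change separates these compounds. Nothing measured here accounts for either step.

Still open, from the compounds shown here alone, is whether benzyl or ethyl on the aromatic nitrogen, or an amine or a carboxylic acid in place of that oxygen, would take the number beyond the scatter.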